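Swapping the Ring Substituent While Holding the Configuration

This account rests on a few compounds, and the source may have more. Where it says the series, first, only, none or still open, it means among the compounds named here.

Compound 2 `CC(C)c1ccccc1NC(=O)N[C@@H](C)c1ccccc1` gives 93% in an ADME assay on the whole organism with Oryza sativa as the target, tested at 10 uM (a higher number here means a weaker effect of the compound at the concentration tested, a lower number a stronger effect), the highest of the three numbers in hand. Compound 1 `CC(C)c1ccccc1NC(=O)N[C@H](C)c1ccccc1` gives 17%, and compound 3 `CC(C)c1ccc(NC(=O)N[C@H](C)c2ccccc2)cc1` gives 49%. Among the compounds with values here, the only step between two measured compounds that differ in a single place is a number 76 percentage points higher from compound 1 to compound 2 (beyond the scatter), and it rests on the fact that compounds 1 and 2 differ only in the configuration as drawn: the same atoms and bonds, a different configuration at the saturated chain carbon.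

Compound 4 `C[C@H](NC(=O)Nc1ccccc1Cl)c1ccccc1` is not yet measured. From compound 2 it differs by chloro in place of isopropyl on an aromatic carbon. The configuration at the saturated chain carbon is kept as it is drawn in compound 2.

Within the data shown here, no measured step exchanges one group on the aromatic ring for another, so nothing in hand bears directly on the change from compound 2 to compound 4. Among the measured compounds shown here, the one step that does exist, a number 76 percentage points higher from compound 1 to compound 2 (beyond the scatter), concerns configuration alone, and that element is left untouched here. The expectation is therefore anchored on compound 2 with a wide margin, and a step of a number 11 percentage points lower from compound 2 to compound 4 (beyond the scatter) is estimated, within the scatter. Compound 4 is expected to give 82%, with a range from 50% to 100% in this assay.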

Compound 4, a percentage reported as activity, at one concentration (the size of the read-out at that concentration, not a potency): 106%
Estimate against measurement, compound 4: 24 percentage points below; the whole stated range lies below it.
By their numbers in this assay, from the lowest: compound 1; then compound 3; then compound 2; then compound 4.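

In this assay, within the data shown here, the exchange of isopropyl for chloro on an aromatic carbon, ortho to a large group, is the first measured change of a ring substituent, and it gives a number 13 percentage points higher from compound 2 to compound 4 (beyond the scatter). The step is modest but beyond the scatter, so the group at this position still registers with the configuration held as drawn in compound 2, and the move runs toward a weaker effect at the concentration tested, starting from a compound that already had the highest number of those before it. Among these compounds, nothing measured so far bears on why chloro gives the higher number here.

Whether the same exchange would shift the number in the same direction and by a similar size in the opposite configuration, the one drawn in compound 1, remains open, since the step shown was read only in the configuration of compound 2. Also open, going by these compounds, is how other groups at this aromatic carbon, such as a methyl, a methoxy group or an amine, would read in this assay.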